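The source may hold more compounds than are shown below. What is called first, only, known or untested is meant among the compounds shown, and "the series" means these compounds.

Measured so far in a physicochemical assay for lipophilicity, read by NMR; on this read-out lower numbers stand for lower lipophilicity and higher numbers for higher lipophilicity:

Compound 1, `CCCOc1ccc2[nH]ccc2c1`, gives 2.9.
Compound 2, `FC(F)(F)CCOc1ccc2[nH]ccc2c1`, gives 2.8.
Compound 3, `CCOC(=O)[C@@H]1CCCN1C(C)=O`, gives 0.

Compound 1 and compound 2 share one core and differ in a single spot: trifluoromethyl in place of methyl on a saturated chain carbon, two bonds along the chain from an oxygen on an aromatic ring. This change made a step of a number 0.10 log units lower from compound 1 to compound 2 (within the scatter).

Compound 3 stands on a different core. The difference between the core of compound 1 and the core of compound 3 is not broken down here; what can be said is that compound 3 sits far below both others in this assay.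

Compound 4, `CC(=O)N1CCC[C@H]1C(=O)OCC(F)(F)F`, has not been measured yet. It comes from compound 3 by trifluoromethyl in place of methyl on a saturated chain carbon bound to an oxygen next to a carbonyl group. Going by the values given here, this is the same kind of change as the one from compound 1 to compound 2, but the surroundings differ: in compound 2 the new group sits on a saturated chain carbon, two bonds along the chain from an oxygen on an aromatic ring, whereas in compound 4 it sits on a saturated chain carbon bound to an oxygen next to a carbonyl group.

The step from compound 3 to compound 4 in this assay is expected to be about no change at the digits printed from compound 3 to compound 4 (within the scatter), resting on the small step seen from compound 1 to compound 2 of a number 0.10 log units lower from compound 1 to compound 2 (within the scatter). For compound 4 the expected value is 0, with a likely range from -0.4 to 0.4.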

Compound 4, partition coefficient: 0.55
Compound 4: middle estimate off by 0.55 log units, on the low side, and the stated range ends below it.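

In this assay, the same exchange of methyl for trifluoromethyl gave a step of a number 0.10 log units lower from compound 1 to compound 2 (within the scatter) on one core, but a step of a number 0.55 log units higher from compound 3 to compound 4 (beyond the scatter) on the other, so the result from the first pair did not carry over unchanged to the second. Going by these compounds alone, with only one pair on each core, and with the change also standing in different surroundings, this does not show whether the core, those surroundings or something else sets the size of the step. Nothing measured here explains why the two steps differ.

The compounds shown leave open how this assay would read with a longer chain, an amine or a carboxylic acid in place of the trifluoromethyl group. They also leave open whether the same exchange on a third core would resemble either of these two steps or give a different one.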